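Swapping the aryl group: trifluoromethoxyphenyl to naphthyl

A few compounds are considered here, and "the series" means these few. Any claim that something is new, unique, unknown or untested is made for them only; others in the source may bear on it.

Compound 1: `O=C(O)CC(NC(=O)NNC(=O)CCCCNc1ccccn1)c1ccc(Br)cc1`, 2.47
Compound 2: `O=C(O)CC(NC(=O)NNC(=O)CCCCNc1ccccn1)c1ccc(OC(F)(F)F)cc1`, 3.17

Of the compounds shown here, two have been measured in a physicochemical assay for lipophilicity; a lower number here means a more polar compound, a higher number a more lipophilic compound. Compound 1 `O=C(O)CC(NC(=O)NNC(=O)CCCCNc1ccccn1)c1ccc(Br)cc1` gives 2.47, and compound 2 `O=C(O)CC(NC(=O)NNC(=O)CCCCNc1ccccn1)c1ccc(OC(F)(F)F)cc1` gives 3.17. Going by the values given here, compound 2 therefore stands higher of the two, and its only neighbour is compound 1: the single measured step, trifluoromethoxy in place of bromo on an aromatic carbon, amounts to a number 0.70 log units higher from compound 1 to compound 2 (beyond the scatter).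

Compound 3 `O=C(O)CC(NC(=O)NNC(=O)CCCCNc1ccccn1)c1cccc2ccccc12` has not yet been measured in this assay. It differs from compound 2 in one place: naphthalen-1-yl in place of 4-(trifluoromethoxy)phenyl on a saturated chain carbon bound to an amide-type nitrogen and a saturated chain carbon. Among the compounds with values here, no measured step exchanges a whole aryl group, so the step from compound 1 to compound 2 bears on it only as a sign that changes at this position have moved this assay by a modest amount. Taking both groups as broadly alike in this respect, the step from compound 2 to compound 3 is expected to be a number 0.13 log units higher from compound 2 to compound 3 (within the scatter), within the scatter or little beyond it. Compound 3 is accordingly estimated at 3.3, in a range from 2.8 to 3.8.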

Compound 3, partition coefficient: 2.64
Compound 3: the middle estimate sits 0.66 log units above what was measured; measured number below the stated range.
By their numbers in this assay, from the lowest: compounds 1 and 3 (each within the scatter of the next); then compound 2.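

In this assay, going by these compounds alone, the whole aryl group on the saturated chain carbon bound to an amide-type nitrogen and a saturated chain carbon was exchanged for the first time, and naphthalen-1-yl in place of 4-(trifluoromethoxy)phenyl gives a number 0.53 log units lower from compound 2 to compound 3 (beyond the scatter) and shows that the read-out responds to a change of the entire group, not only to a change of the substituent on a phenyl ring. Naphthalen-1-yl in place of 4-bromophenyl gives a number 0.17 log units higher from compound 1 to compound 3 (within the scatter) and leaves compound 1 and compound 3 indistinguishable despite their different ring counts, so among these three compounds only compound 2, whose steps to both others lie beyond the scatter, stands apart. No measurement is available to explain why 4-(trifluoromethoxy)phenyl separates from the other two groups.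

The compounds shown leave open whether this separation is particular to the trifluoromethoxy group or would also appear with a methoxy group, a trifluoromethyl group or a chlorine on the phenyl ring. They also leave open where an unsubstituted phenyl or a pyridine ring at this position would fall relative to these three compounds.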